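A few compounds are considered here, and "the series" means these few. Any claim that something is new, unique, unknown or untested is made for them only; others in the source may bear on it.

In an assay on isolated protein for inhibition of Rho-associated protein kinase 1 (Homo sapiens), tested at 30 uM (on this read-out lower numbers stand for less inhibition and higher numbers for more inhibition at the one concentration tested (going by the name of the read-out)), the three measured compounds come from two different cores. Compound 1 `Fc1ccc(Sc2[nH]cnc3nccc2-3)cc1` gives 42%, and compound 2 `Cn1cnc2c(Sc3ccc(F)cc3)ncnc21` gives 6%. Compound 3 `c1ccc(-[n+]2c[nH]c3ncncc32)cc1` gives 0%; its number is the lowest of the three, though the gap to compound 2 lies within the usual scatter of this kind of measurement, and only the gap to compound 1 lies beyond it. Going by the values given here, no step between two measured compounds that differ in a single place is available, so the size of such a change here has not been seen directly.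

Compound 4 `Fc1ccc(-[n+]2c[nH]c3ncncc32)cc1` differs from compound 3 in one place: fluoro in place of hydrogen on an aromatic carbon on an aromatic carbon of a six-membered aromatic ring of carbon only. With compound 3 giving 0% in this assay, the step from compound 3 to compound 4 is expected to be a number 5 percentage points higher from compound 3 to compound 4 (within the scatter), that is, nothing beyond the scatter in either direction. Compound 4 is therefore estimated to give 5% in this assay, within a range from 0% to 20%.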

Compound 4, a percentage reported as inhibition, at one concentration (the size of the read-out at that concentration, not a potency): 2%
The estimate for compound 4 lay 3 percentage points above the measured number; low and high end bracket the measured number.
By their numbers in this assay, from the lowest: compounds 3, 4 and 2 (each within the scatter of the next); then compound 1.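

In this assay, going by these compounds alone, fluoro in place of hydrogen on an aromatic carbon of a six-membered aromatic ring of carbon only, para to a group of 9 heavy atoms, gives a number 2 percentage points higher from compound 3 to compound 4 (within the scatter) and so supplies the first directly observed single-place step in this set. Within the data shown here, at this position, then, this one exchange does not move the read-out beyond the scatter, although it is only a single step, and its starting point, compound 3, already reads 0% on this scale. Nothing available here bears on the reason for this result.

As far as these compounds go, whether an amine, a carboxylic acid or a longer chain at this same place would shift the number remains open. So does whether fluoro in place of hydrogen would have a similarly small effect on the core of compound 1, where the number is higher.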